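This account rests on a few compounds, and the source may have more. Where it says the series, first, only, none or still open, it means among the compounds named here.

Measured compounds in a functional assay on A549 cells (Homo sapiens) for antiproliferative activity, read by MTT assay, with a stated time of 72 h; a lower number here means a stronger inhibitor, a higher number a weaker inhibitor:
- compound 1 `CC(C)(C)c1cn(C[C@H](O)[C@H]2OC(=O)C(OCc3ccccc3)=C2OCc2ccccc2)nn1`: 34000 nM
- compound 3 `O=C1O[C@H]([C@@H](O)Cn2cc(-c3ccc(Br)cc3)nn2)C(OCc2ccccc2)=C1OCc1ccccc1`: 750 nM
- compound 2 `COc1ccccc1-c1cn(C[C@H](O)[C@H]2OC(=O)C(OCc3ccccc3)=C2OCc2ccccc2)nn1`: in this assay compound 2 gives > 100000 nM, which is a limit of the assay rather than a number.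

Compound 3 holds the lowest of the two numbers; the step from tert-butyl to 4-bromophenyl is a 45-fold lower number from compound 1 to compound 3 (1.66 log units; beyond the scatter). The step from compound 2 is an at least 130-fold lower number from compound 2 to compound 3 (2.12 log units; beyond the scatter), though it rests on a limit (the limit of > 100000 nM in this assay, at which 1 of the 3 values shown sits).

Compound 4 `O=C1O[C@H]([C@@H](O)Cn2ccnn2)C(OCc2ccccc2)=C1OCc1ccccc1` differs from compound 3 by hydrogen in place of 4-bromophenyl on an aromatic carbon. Both measured steps onto this carbon, a 45-fold lower number from compound 1 to compound 3 (1.66 log units; beyond the scatter) and an at least 130-fold lower number from compound 2 to compound 3 (2.12 log units; beyond the scatter), show that the 4-bromophenyl group drives the low number of compound 3. Removing it for hydrogen is therefore expected to raise the number by a large step in this assay, a 67-fold higher number from compound 3 to compound 4 (1.82 log units; beyond the scatter). Compound 4 is estimated at 50000 nM, within 10000 nM to 150000 nM.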

Compound 4, half-maximal inhibitory concentration: > 100000 nM
Compound 4: only a limit was reported; the forecaster's own chance of this, stated with the estimate: 35%; at least 2.0-fold (0.30 log units) between middle value and limit.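

Compound 4 gives only a limit of the assay in this assay, not a number: the limit of > 100000 nM in this assay, at which 2 of the 4 values shown sit.

Hydrogen on this aromatic carbon trails both measured substituents, with an at least 130-fold higher number from compound 3 to compound 4 (2.12 log units; beyond the scatter) and an at least 2.9-fold higher number from compound 1 to compound 4 (0.46 log units; beyond the scatter), so the shared core alone does not reach the lower numbers, and even tert-butyl improves on hydrogen. The step involving compound 2 cannot be read, since both of its ends are limits.

Still open, going by these compounds, is whether the bromine or the phenyl ring carries the effect of 4-bromophenyl. Plain phenyl, 4-chlorophenyl or 4-aminophenyl on this carbon would separate the two.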